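Chloro in place of ethyl on the shared core

A few compounds are considered here, and "the series" means these few. Any claim that something is new, unique, unknown or untested is made for them only; others in the source may bear on it.

Of the compounds shown here, two have numbers so far. Compound 1 `C=C(Br)C(=O)Nc1cccc(-c2cn3nc(-c4ccc(C)cc4)sc3n2)c1` gives 1200 nM in a functional assay on FM3A cells (Mus musculus) for inhibition, read by cell counting, with a stated time of 2 days; on this read-out higher numbers stand for weaker inhibition and lower numbers for stronger inhibition. Compound 2 `CCc1ccc(-c2nn3cc(-c4cccc(N)c4)nc3s2)cc1` gives 8200 nM in this assay, the highest of the two numbers shown; its nearest neighbour is compound 1, whose number is lower by a gap that lies beyond the scatter. Within the data shown here, the two differ in more than one place, so no single step between them can be read off.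

Compound 3 `Nc1cccc(-c2cn3nc(-c4ccc(Cl)cc4)sc3n2)c1` has not yet been measured in this assay. It keeps the free amine of compound 2 and differs from it in one place: chloro in place of ethyl on an aromatic carbon. Among the measured compounds shown here, no pair of measured compounds differs by this change alone, so no step of this kind is known here. The expectation for the step in this assay is therefore modest, no larger than the scatter, with no firm direction; a slight move toward a lower number is the estimate, giving a 1.4-fold lower number from compound 2 to compound 3 (0.14 log units; within the scatter). On that basis compound 3 is expected to give about 6000 nM in this assay, with a range from 2000 nM to 20000 nM.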

Compound 3, half-maximal inhibitory concentration: 160000 nM
Compound 3: middle estimate off by 27-fold (1.43 log units), on the low side, outside the stated range (above it).
By their numbers in this assay, from the lowest: compound 1; then compound 2; then compound 3.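

In this assay, chloro in place of ethyl on an aromatic carbon, para to a large group, gives a 20-fold higher number from compound 2 to compound 3 (1.29 log units; beyond the scatter), with the free amine and the shared core unchanged. Among these compounds, this is the first single-place step available, and it shows that the group at this position is not a neutral handle: this one exchange alone moves the read-out well beyond the scatter, toward weaker inhibition. Nothing shown here accounts for the size or direction of this step.

The compounds shown leave open whether ethyl is favoured as a particular group or whether other groups at this position would give similar numbers; a methyl, a longer chain such as propyl, a methoxy or a fluoro, each set on the same aromatic carbon with the free amine kept, would separate these readings. Also open, going by these compounds, is whether the step carries over when the free amine gives way to the bromine-bearing amide of compound 1, since the present step rests on a single pair.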